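The compounds below may be only part of what the source reports. "The series", "measured", "known", "first", "only" and "open" are said of these compounds alone.

In an ADME assay on MSTO-211H cells (Homo sapiens) for inhibition, read by trypan blue exclusion, with a stated time of 72 h (a lower number here means a stronger inhibitor of growth, a higher number a weaker inhibitor of growth), the measured compounds stand as follows:
- compound 1, `O=C(/C=C/c1ccccc1)c1ccccc1[N+](=O)[O-]`, gives 9800 nM
- compound 2, `COc1ccccc1C(=O)/C=C/c1ccccc1`, gives 9500 nM
- compound 3, `O=C(/C=C/c1ccc(C(F)(F)F)cc1)c1ccccc1`, gives 7000 nM

Compound 2 holds the second highest of the three numbers; its value and that of compound 1 lie within the scatter of each other, and the same is true of compound 2 against compound 3, so the three values are not separated in this assay.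

The next compound, compound 4, `O=C(/C=C/c1ccccc1)c1ccccc1C(F)(F)F`, differs from compound 2 in one place: trifluoromethyl in place of methoxy on an aromatic carbon. Among the measured compounds shown here, the one measured step that bears on it is the change at the same position, a 1.0-fold lower number from compound 1 to compound 2 (0.01 log units; within the scatter), which swapped one group for another on that aromatic carbon without moving the number beyond the scatter. Compound 3 carries a trifluoromethyl group, though on the other ring, and its number again sits close to those of compound 1 and compound 2. For the measured compounds named here, no measured step here moves the number beyond the scatter, so for compound 4 a step of no more than a 1.1-fold lower number from compound 2 to compound 4 (0.05 log units; within the scatter) is expected in this assay. Compound 4 is therefore estimated at 8500 nM, with a range from 4000 nM to 18000 nM.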

Compound 4, concentration for 50% growth inhibition: 8500 nM
For compound 4 middle estimate and measured number coincide at the digits printed; the range from low to high includes it.
By their numbers in this assay, from the lowest: compounds 3, 4, 2 and 1 (each within the scatter of the next).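

In this assay the aromatic carbon ortho to a large group has now carried nitro, methoxy and trifluoromethyl, and trifluoromethyl in place of methoxy gives a 1.1-fold lower number from compound 2 to compound 4 (0.05 log units; within the scatter) while trifluoromethyl in place of nitro gives a 1.2-fold lower number from compound 1 to compound 4 (0.06 log units; within the scatter) at this same place. Trifluoromethyl has more heavy atoms than methoxy and no hydrogen-bond acceptor, yet neither difference separates compound 4 from compound 2, so these three groups remain indistinguishable at this position. Nothing shown explains why the number stays flat across this change.

Still open, from the compounds shown here alone, is whether an amine, a carboxylic acid or a longer chain such as ethoxy at this position would move the number beyond the scatter. Also open, going by these compounds, is how the core with only hydrogen at this position compares with compound 1, compound 2 and compound 4.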